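A few compounds are considered here, and "the series" means these few. Any claim that something is new, unique, unknown or untested is made for them only; others in the source may bear on it.

Measured compounds:
compound 1, `C=C1C(=O)[C@]23C[C@@]1(O)CC[C@H]2c1ccc(O)c(C)c1[C@@H]3Cn1cc(-c2ccc(F)cc2)nn1`, 1700 nM
compound 2, `C=C1C(=O)[C@]23C[C@@]1(O)CC[C@H]2c1ccc(O)c(C)c1[C@@H]3Cn1cc(-c2ccc(C)cc2)nn1`, 370 nM
compound 3, `C=C1C(=O)[C@]23C[C@@]1(O)CC[C@H]2c1ccc(OS(=O)(=O)c2ccc(C)cc2)c(C)c1[C@@H]3Cn1cc(-c2ccc(F)cc2)nn1`, 330 nM

All three values come from a functional assay on MCF7 cells (Homo sapiens) for cytotoxicity, read by MTT assay, with a stated time of 4 days; on this read-out lower numbers stand for stronger inhibition and higher numbers for weaker inhibition. Compound 1 and compound 2 differ only by methyl in place of fluoro on an aromatic carbon, and this change gives a 4.6-fold lower number from compound 1 to compound 2 (0.66 log units; beyond the scatter). Compound 3 carries a different core: it differs from compound 1 by (4-methylphenyl)sulfonyl in place of hydrogen on an oxygen on an aromatic ring, and that change gives a 5.2-fold lower number from compound 1 to compound 3 (0.71 log units; beyond the scatter). Compound 2 and compound 3 lie within the scatter of each other in this assay, so no order between them is claimed.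

Compound 4, `C=C1C(=O)[C@]23C[C@@]1(O)CC[C@H]2c1ccc(OS(=O)(=O)c2ccc(C)cc2)c(C)c1[C@@H]3Cn1cc(-c2ccc(C)cc2)nn1`, is not yet measured. It differs from compound 3 by methyl in place of fluoro on an aromatic carbon, the same change as between compound 1 and compound 2, placed here on the core of compound 3. The expectation rests on that single measured instance: because a 4.6-fold lower number from compound 1 to compound 2 (0.66 log units; beyond the scatter) was seen on the core of compound 1, a step of similar size is expected in this assay, a 3.7-fold lower number from compound 3 to compound 4 (0.56 log units; beyond the scatter), with the caveat that one example cannot show whether the change carries over unchanged onto the other core. Compound 4 is estimated at 90 nM, expected between 35 nM and 250 nM.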

Compound 4, half-maximal inhibitory concentration: 320 nM
The estimate for compound 4 lay 3.6-fold (0.55 log units) below the measured number, and the stated range ends below it.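

On the core of compound 3, methyl in place of fluoro gives a 1.0-fold lower number from compound 3 to compound 4 (0.01 log units; within the scatter) in this assay, so the step seen on the core of compound 1 does not carry over to this core: the same change on two cores in this assay, a 4.6-fold lower number (0.66 log units; beyond the scatter) from compound 1 to compound 2 and a 1.0-fold lower number (0.01 log units; within the scatter) from compound 3 to compound 4, 4.5-fold (0.65 log units) apart, beyond the scatter of two such steps Likewise, (4-methylphenyl)sulfonyl in place of hydrogen on the oxygen gives a 1.2-fold lower number from compound 2 to compound 4 (0.06 log units; within the scatter) when the methyl group is already present, so across these four compounds the two changes do not add: the same change on two cores in this assay, a 5.2-fold lower number (0.71 log units; beyond the scatter) from compound 1 to compound 3 and a 1.2-fold lower number (0.06 log units; within the scatter) from compound 2 to compound 4, 4.5-fold (0.65 log units) apart, beyond the scatter of two such steps This rests on a single pair of steps for each change; it shows that the size of each step depends on the other group present in these compounds, but not why, nor whether the same holds for any other pair of groups.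

Still open, on these data alone, is whether a methoxy group or a nitrile on that aromatic carbon would follow fluoro or methyl on either core. Also open, as far as these compounds go, is whether an acetyl group on the oxygen would give a step like that of (4-methylphenyl)sulfonyl.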